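A few compounds are considered here, and "the series" means these few. Any claim that something is new, unique, unknown or untested is made for them only; others in the source may bear on it.

Compound 1, `CC1(c2ccc(NC(c3ccc(F)cc3)c3nnnn3C(C)(C)C)cc2)NC(=O)c2ccccc2N1`, gives "not determined" (no result reported) in an ADME assay on Vero cells (Chlorocebus sabaeus) for cytotoxicity, read by MTT assay, with a stated time of 72 h (a higher number here means that more compound is tolerated, a lower number that less compound is tolerated), meaning that no result is reported for it.
Compound 2, `CC(C)c1ccc(C(Nc2ccc(C3(C)NC(=O)c4ccccc4N3)cc2)c2nnnn2C(C)(C)C)cc1`, gives > 400000 nM in this assay, which is a limit of the assay rather than a number.
Compound 3, `CC1(c2ccc(NC(c3ccc(Br)cc3)c3nnnn3C(C)(C)C)cc2)NC(=O)c2ccccc2N1`, gives > 400000 nM in this assay, again a limit of the assay.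

Compound 3 therefore stands at the limit, where compound 2 also sits, while compound 1 offers no value at all. For the measured compounds named here, the only step measured between these compounds, a step that the two limits leave unreadable from compound 2 to compound 3, is bromo in place of isopropyl on an aromatic carbon, and its size cannot be read because both ends rest at the limit of > 400000 nM in this assay, at which 2 of the 3 values shown sit.

Compound 4, `COc1ccc(C(Nc2ccc(C3(C)NC(=O)c4ccccc4N3)cc2)c2nnnn2C(C)(C)C)cc1`, differs from compound 3 as methoxy in place of bromo on an aromatic carbon. Going by the values given here, no measured step speaks to this particular change, and the one step available is unreadable. With two compounds of this set already at the limit, compound 4 is expected to be tolerated to the same extent, giving an estimate of 400000 nM with a range of 200000 nM to 800000 nM. The step of a number no higher from compound 3 to compound 4 (the limit leaves the size open) is expected to be none beyond the scatter, and most likely the assay will again report only a limit.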

Compound 4, half-maximal cytotoxic concentration: > 400000 nM
Compound 4 gave a limit, no number; the forecaster's own chance of this, stated with the estimate: 85%; the middle value sits exactly at the limit.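

In this assay compound 4 rests at a limit, as do compound 2 and compound 3, so the steps among these three compounds cannot be read: the limit of > 400000 nM in this assay, at which 3 of the 4 values shown sit. The compounds shown leave open whether the isopropyl, bromo and methoxy groups differ in how well the cells tolerate them.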